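The source may report more compounds than this note shows. Statements on the series, on what has been measured and on what is new or still open speak of the compounds shown alone.

Working notes on the series. For the measured compounds named here, in a functional assay on cells (Erythrocyte, Homo sapiens) for inhibition, read by spectrophotometry and hemolysis, with a stated time of 10 min (on this read-out lower numbers stand for stronger inhibition and higher numbers for weaker inhibition), compound 1 (`O=C(CCc1nc2ccccc2c(=O)[nH]1)N/N=C/c1ccc([N+](=O)[O-])cc1`) gives 54000000 nM, the lowest of the two numbers measured so far. Compound 2 (`COc1cc(/C=N/NC(=O)CCCc2nc3ccccc3c(=O)[nH]2)cc(O)c1O`) gives 277000000 nM, and the gap between the two values lies beyond the usual scatter.

Compound 3 (`O=C(CCc1nc2ccccc2c(=O)[nH]1)N/N=C/c1cc(O)c(O)c(O)c1`) has not yet been measured. It differs from compound 1 in one place, with 3,4,5-trihydroxyphenyl in place of 4-nitrophenyl on a carbon with a double bond to nitrogen.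

Going by the values given here, no measured pair isolates a change of this kind, so the size of the step in this assay cannot be read directly from the data. Among the compounds with values here, the only guide is the span of the two values. With compound 1 at the low end at 54000000 nM, a move to a higher number is the more likely direction, and a move to a lower one cannot be excluded. The expected step, a 2.4-fold higher number from compound 1 to compound 3 (0.38 log units; beyond the scatter), is of moderate size and stays inside that span. For compound 3 the estimated value is 130000000 nM, with an expected range from 35000000 nM to 450000000 nM.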

Compound 3, half-maximal inhibitory concentration: 203000000 nM
Compound 3: middle estimate off by 1.6-fold (0.19 log units), on the low side; measured number inside the range.
By their numbers in this assay, from the lowest: compound 1; then compounds 3 and 2 (each within the scatter of the next).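

In this assay the series now has its first step that changes one place only: 3,4,5-trihydroxyphenyl in place of 4-nitrophenyl on a carbon with a double bond to nitrogen gives a 3.8-fold higher number from compound 1 to compound 3 (0.58 log units; beyond the scatter) and so shows that inhibition responds to the group held at this position. The exchange keeps the heavy-atom count and the six-membered aromatic ring of carbon only, while the entering group has hydrogen-bond donors and the leaving group has none, so the step follows a change in the substituents on that ring and not in its number of heavy atoms. Nothing available explains the step or assigns it to a particular feature of either group.

For the compounds shown here, compound 2 differs from compound 1 and from compound 3 in more than one place, so no step to it can be read, and the effect of a longer chain alone remains open. Also open, going by these compounds, is where an aromatic ring with no substituents, or one carrying an amine or a carboxylic acid, would fall relative to compound 1 and compound 3.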